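The compounds below may be only part of what the source reports. "The series", "measured", "known", "first", "only" and "open" are said of these compounds alone.

Of the compounds shown here, two with a shared core have so far been measured in a functional assay on A2780 cells (Homo sapiens) for inhibition; a higher number here means a weaker inhibitor, a lower number a stronger inhibitor. Compound 1 `CC(C(=O)Nc1cc(C2CC2)[nH]n1)c1ccc(N2CCC(C(N)=O)C2=O)cc1` gives 5710 nM, and compound 2 `CC(C(=O)Nc1cc(C2CC2)[nH]n1)c1ccc(N2CCCS2(=O)=O)cc1` gives 5240 nM. Going by the values given here, compound 2 therefore stands level with compound 1, its only neighbour on the scale. Among the compounds with values here, the one measured step, a 1.1-fold lower number from compound 1 to compound 2 (0.04 log units; within the scatter), lies within the scatter of repeated measurements, so neither can be called the stronger inhibitor.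

Compound 3 `CC(C(=O)Nc1cc(C2CC2)[nH]n1)c1ccc(N2CC(=O)NC2=O)cc1` keeps the shared core and exchanges only the ring on an aromatic carbon, para to a large group: a group of 7 heavy atoms (3 carbon, 2 nitrogen, 2 oxygen; one five-membered non-aromatic ring with 2 hetero atoms) in place of a group of 7 heavy atoms (3 carbon, 1 nitrogen, 2 oxygen, 1 sulfur; one five-membered non-aromatic ring with 2 hetero atoms), on an aromatic carbon. The entering group is 2,4-dioxoimidazolidin-1-yl. Within the data shown here, the only evidence bearing on this exchange is that same measured step, a different swap of ring groups on an aromatic carbon, and its size stayed within the scatter. Among the measured compounds shown here, one step is thin evidence, and no measured compound yet carries the new group. What is expected in this assay is therefore no step beyond the scatter in either direction, an estimated 1.0-fold higher number from compound 2 to compound 3 (0.02 log units; within the scatter). For compound 3 the expected value is about 5500 nM, with an estimated range from 2000 nM to 15000 nM.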

Compound 3, half-maximal inhibitory concentration: 4540 nM
For compound 3 the middle estimate is 1.2-fold (0.08 log units) above the measured one; low and high end bracket the measured number.
By their numbers in this assay, from the lowest: compounds 3, 2 and 1 (each within the scatter of the next).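

In this assay, putting 2,4-dioxoimidazolidin-1-yl on this aromatic carbon, para to a large group, gives a 1.2-fold lower number from compound 2 to compound 3 (0.06 log units; within the scatter) and, measured against the larger ring group of compound 1, gives a 1.3-fold lower number from compound 1 to compound 3 (0.10 log units; within the scatter) as well. Three different five-membered non-aromatic rings now sit level at this position, where the earlier pair offered only two. The entering ring also has a hydrogen-bond donor where the ring it replaces has none and a second nitrogen in place of sulfur, yet neither exchange goes with a step beyond the scatter, and no measurement here explains why these rings read alike.

As far as these compounds go, all three compounds carry a five-membered non-aromatic ring at this place, so it remains open whether a simple amine, a carboxylic acid, a longer alkyl chain or a six-membered morpholine ring would produce a step beyond the scatter. From the compounds shown here alone, it also remains open whether this position can move the number at all, or whether a change elsewhere on the shared core would be needed to do so.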